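Swapping Trifluoromethyl for Fluoro in a Cytotoxicity Series

The source may hold more compounds than are shown below. What is called first, only, known or untested is meant among the compounds shown, and "the series" means these compounds.

Three analogues sharing one core have been tested for cytotoxicity. Compound 1 `Cc1cc(-c2ccccc2C(F)(F)F)cc(C)c1Nc1ccnc(Nc2ccc(C#N)cc2)n1` gives 4210 nM in an ADME assay on MT4 cells (Homo sapiens) for cytotoxicity, read by MTT assay, with a stated time of 4 days; on this read-out lower numbers stand for higher toxicity in this test and higher numbers for lower toxicity in this test. Compound 2 `COc1cccc(-c2cc(C)c(Nc3ccnc(Nc4ccc(C#N)cc4)n3)c(C)c2)c1` gives 2990 nM in this assay, and compound 3 `Cc1cc(-c2ccc(C(F)(F)F)cc2)cc(C)c1Nc1ccnc(Nc2ccc(C#N)cc2)n1` gives 4160 nM, the second highest of the three numbers. The neighbouring steps a 1.0-fold lower number from compound 1 to compound 3 (0.01 log units; within the scatter) and a 1.4-fold higher number from compound 2 to compound 3 (0.14 log units; within the scatter) stay within the scatter, as does a 1.4-fold lower number from compound 1 to compound 2 (0.15 log units; within the scatter). Compound 4 `Cc1cc(-c2ccc(F)cc2)cc(C)c1Nc1ccnc(Nc2ccc(C#N)cc2)n1` differs from compound 3 by fluoro in place of trifluoromethyl on an aromatic carbon. No measured step replaces a trifluoromethyl with a fluoro, but since every exchange among these pendant groups left the read-out unmoved, one expects compound 4 to show no step beyond the scatter, a 1.1-fold higher number from compound 3 to compound 4 (0.03 log units; within the scatter). The estimate for compound 4 in this assay is 4500 nM, between 2500 nM and 8500 nM.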

Compound 4, half-maximal cytotoxic concentration: 4170 nM
Compound 4: the middle estimate sits 1.1-fold (0.03 log units) above what was measured; measured number inside the range.
By their numbers in this assay, from the lowest: compounds 2, 3, 4 and 1 (each within the scatter of the next).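

In this assay, cutting trifluoromethyl down to a single fluoro, from four heavy atoms to one, leaves the read-out unmoved, with a 1.0-fold higher number from compound 3 to compound 4 (0.00 log units; within the scatter). The 4-fluorophenyl group also stays level with the other pendant groups, with a 1.4-fold higher number from compound 2 to compound 4 (0.14 log units; within the scatter) and a 1.0-fold lower number from compound 1 to compound 4 (0.00 log units; within the scatter). No measurement is available to explain this flat response.

The compounds shown leave open whether an amine, a carboxylic acid or a longer chain in the same place would also leave the number unmoved. They include no group that moves it beyond the scatter.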